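Cytotoxicity notes on quinoline ether amides

The source may hold more compounds than are shown below. What is called first, only, known or untested is meant among the compounds shown, and "the series" means these compounds.

Measured so far:
compound 1 `COc1ccc2nc(C(F)(F)F)cc(OCC(=O)Nc3cc(C)cc(C)c3)c2c1`, > 100000 nM
compound 2 `COc1ccc2nc(C)cc(OC3CCN(c4ccccc4)C3=O)c2c1`, 100000 nM
compound 3 `COc1ccc2nc(C)cc(OCC(=O)Nc3cccc(C)c3)c2c1`, 39800 nM

In a toxicity assay on HepG2 cells (Homo sapiens) for inhibition, read by CellTiter-Glo, with a stated time of 48 h (on this read-out higher numbers stand for weaker inhibition and lower numbers for stronger inhibition), compound 1 reaches only a limit, > 100000 nM, and gives no number. Compound 2 gives 100000 nM and compound 3 gives 39800 nM; of the two numbers shown, compound 3 carries the lower one, and the gap to compound 2 lies beyond the scatter. Compound 4 `COc1ccc2nc(C)cc(OCC(=O)Nc3ccc(F)cc3)c2c1` is not yet measured in this assay. It differs from compound 3 by 4-fluorophenyl in place of 3-methylphenyl on an amide-type nitrogen. Among the compounds with values here, with no measured step of this kind, the change is expected to move the number little, if anything upward: the step from compound 3 to compound 4 is estimated at a 1.4-fold higher number from compound 3 to compound 4 (0.14 log units; within the scatter). Compound 4 is thus expected near 55000 nM, within 20000 nM to 150000 nM.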

Compound 4, half-maximal inhibitory concentration: 63100 nM
Compound 4: the middle estimate sits 1.1-fold (0.06 log units) below what was measured; the range from low to high includes it.
By their numbers in this assay, from the lowest: compounds 3, 4 and 2 (each within the scatter of the next, the first and the last beyond it).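

Within the data shown here, replacing 3-methylphenyl with 4-fluorophenyl on the amide-type nitrogen gives a 1.6-fold higher number from compound 3 to compound 4 (0.20 log units; within the scatter) in this assay, the first reading at this position. Within this pair, the aryl group changes without a shift that can be told from the scatter. Both compounds give numbers rather than a limit, so the step can be read directly: the limit of > 100000 nM in this assay, at which 1 of the 4 values shown sits.

From the compounds shown here alone, whether the number stays as flat with an amine or a carboxylic acid on the aryl ring remains open. This single step also cannot separate the contributions of the methyl and the fluorine.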